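Cytotoxicity notes: methoxy to chloro on a shared core

A few compounds are considered here, and "the series" means these few. Any claim that something is new, unique, unknown or untested is made for them only; others in the source may bear on it.

Compound 1 `COc1ccc2[nH]c(C)c(Cc3ccccc3)c(=O)c2c1` carries a methoxy group. In an ADME assay on J774 cells (Mus musculus) for cytotoxicity (on this read-out lower numbers stand for an effect already at smaller amounts and higher numbers for an effect only at larger amounts of compound), compound 1 gives only a limit, > 23700 nM. Compound 2 `Cc1[nH]c2ccc(Cl)cc2c(=O)c1Cc1ccccc1` differs from it by chloro in place of methoxy on an aromatic carbon. In this assay compound 2 likewise gives a limit, > 35200 nM. The step that the two limits leave unreadable from compound 1 to compound 2 therefore cannot be read. Compound 3 `COc1cccc2c(=O)c(Cc3ccccc3)c(C)[nH]c12` has the same atoms as compound 1, joined differently; the difference between the two cores is not broken down here. In this assay compound 3 gives a limit, > 35800 nM. Compound 4 `Cc1[nH]c2c(Cl)cccc2c(=O)c1Cc1ccccc1` is not yet measured; it differs from compound 3 by chloro in place of methoxy on an aromatic carbon, the same kind of change as from compound 1 to compound 2, here ortho to a fused ring and meta to a fused ring rather than meta to a fused ring and para to a fused ring. Because compound 3 gives > 35800 nM, a limit, the step to compound 4 in this assay is expected to be a step that the limit leaves unreadable from compound 3 to compound 4. The estimate for compound 4 is 36000 nM, with a range from 15000 nM to 100000 nM.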

Compound 4, half-maximal effective concentration: > 35200 nM
Compound 4: only a limit was reported (the forecaster's own chance of this, stated with the estimate: 85%); the middle value does not contradict the limit.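

In this assay compound 3 and compound 4 both give only limits, and the step between them cannot be read. Whether chloro in place of methoxy changes cytotoxicity on either core stays open, with all four compounds shown giving only limits.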